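A few compounds are considered here, and "the series" means these few. Any claim that something is new, unique, unknown or untested is made for them only; others in the source may bear on it.

Compound 2 `N#Cc1c(Cl)nc(SCc2nc3ccccc3[nH]2)nc1-c1ccccc1` gives 11.3 nM in a functional assay on K562 cells (Homo sapiens) for cytotoxicity, read by MTT assay, with a stated time of 3 days (a lower number here means a stronger inhibitor, a higher number a weaker inhibitor), and stands highest of the two numbers recorded; its nearest neighbour is compound 1 `N#Cc1c(O)nc(SCc2nc3ccccc3[nH]2)nc1-c1ccccc1`, which gives 4.63 nM. For the measured compounds named here, the single step so far, a 2.4-fold higher number from compound 1 to compound 2 (0.39 log units; beyond the scatter), was modest. Compound 3 `N#Cc1c(Nc2nccs2)nc(SCc2nc3ccccc3[nH]2)nc1-c1ccccc1` now differs from compound 2 in one place: (1,3-thiazol-2-yl)amino in place of chloro on an aromatic carbon. Going by the values given here, no measured step covers this replacement; the only step available concerns a different group on the same aromatic carbon, so it offers little guidance. A step of about a 1.1-fold higher number from compound 2 to compound 3 (0.03 log units; within the scatter) is therefore expected, not clearly beyond the scatter. For compound 3 the estimate is 12 nM, with a range of 3 nM to 60 nM.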

Compound 3, half-maximal inhibitory concentration: 14.7 nM
Compound 3: the middle estimate sits 1.2-fold (0.09 log units) below what was measured; low and high end bracket the measured number.
By their numbers in this assay, from the lowest: compound 1; then compounds 2 and 3 (each within the scatter of the next).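

On the aromatic carbon ortho to the cyano group, the bulk of the substituent makes little visible difference between these two compounds: (1,3-thiazol-2-yl)amino, with 6 heavy atoms against 1 for chloro, gives a 1.3-fold higher number from compound 2 to compound 3 (0.11 log units; within the scatter) and stays level with chloro. Measured against hydroxy, the same group gives a 3.2-fold higher number from compound 1 to compound 3 (0.50 log units; beyond the scatter) and this modest step separates compound 1 from compound 3. No measured evidence accounts for these numbers.

Still open, as far as these compounds go, is whether a simple amine, a methoxy group or a morpholine on this carbon would sit with hydroxy or with chloro. Also open, from the compounds shown here alone, is whether the 1,3-thiazol-2-yl ring itself matters, which a phenylamino group could test.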